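Notes on the exocyclic substituent: aryl replaced by propyl

A few compounds are considered here, and "the series" means these few. Any claim that something is new, unique, unknown or untested is made for them only; others in the source may bear on it.

Three members of this series have been measured in a functional assay on DU-145 cells (Homo sapiens) for cytotoxicity, read by sulforhodamine B assay, with a stated time of 48 h; on this read-out lower numbers stand for stronger inhibition and higher numbers for weaker inhibition. Compound 1 `CC(=O)OC[C@H]1O[C@@H](n2cc(CN3C(=O)/C(=C/c4ccccc4)c4ccccc43)nn2)[C@H](OC(C)=O)[C@@H](OC(C)=O)[C@@H]1OC(C)=O` gives 22800 nM. Compound 2 `CC(=O)OC[C@H]1O[C@@H](n2cc(CN3C(=O)/C(=C/c4ccc(N(C)C)cc4)c4ccccc43)nn2)[C@H](OC(C)=O)[C@@H](OC(C)=O)[C@@H]1OC(C)=O`, carrying a dimethylamino group, gives 11200 nM, the step of a 2.0-fold lower number from compound 1 to compound 2 (0.31 log units; beyond the scatter). Compound 3 `CC(=O)OC[C@H]1O[C@@H](n2cc(CN3C(=O)/C(=C/c4ccc5ccccc5c4)c4ccccc43)nn2)[C@H](OC(C)=O)[C@@H](OC(C)=O)[C@@H]1OC(C)=O` gives 43700 nM, the highest of the three numbers; the step of a 1.9-fold higher number from compound 1 to compound 3 (0.28 log units; within the scatter) is within the scatter, while the step of a 3.9-fold higher number from compound 2 to compound 3 (0.59 log units; beyond the scatter) lies beyond it.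

Compound 4 `CCC/C=C1/C(=O)N(Cc2cn([C@@H]3O[C@H](COC(C)=O)[C@@H](OC(C)=O)[C@H](OC(C)=O)[C@H]3OC(C)=O)nn2)c2ccccc21` has not yet been measured in this assay. Its difference from compound 3 is propyl in place of naphthalen-2-yl on a double-bonded chain carbon bound to a double-bonded ring carbon: an aromatic system at the exocyclic carbon gives way to a short chain. Among the compounds with values here, both measured steps at that position, a 1.9-fold higher number from compound 1 to compound 3 (0.28 log units; within the scatter) and a 3.9-fold higher number from compound 2 to compound 3 (0.59 log units; beyond the scatter), swap one aromatic group for another and stay modest in size; no measured step removes the aromatic group altogether, so the data give no direct guide to this change. On that basis compound 4 is expected to stay within a modest distance of compound 3, and the estimated step of a 1.1-fold lower number from compound 3 to compound 4 (0.04 log units; within the scatter) is set near no change, with a wide range. The value for compound 4 in this assay is therefore estimated at 40000 nM, between 10000 nM and 150000 nM.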

Compound 4, half-maximal inhibitory concentration: 19700 nM
Beside the measured number, compound 4's estimate is 2.0-fold (0.31 log units) above it, within the range that was stated.
By their numbers in this assay, from the lowest: compounds 2, 4, 1 and 3 (each within the scatter of the next, the first and the last beyond it).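

In this assay, an aromatic group on a double-bonded chain carbon bound to a double-bonded ring carbon is not required for this level of activity: propyl, with no ring and 3 heavy atoms, cannot be told apart from phenyl (a 1.2-fold lower number from compound 1 to compound 4 (0.06 log units; within the scatter)) or from 4-(dimethylamino)phenyl (a 1.8-fold higher number from compound 2 to compound 4 (0.25 log units; within the scatter)). Among the replacements of an aryl group by propyl, only the one from naphthalen-2-yl gives a step beyond the scatter (a 2.2-fold lower number from compound 3 to compound 4 (0.35 log units; beyond the scatter)), and that step remains modest. The series therefore tolerates a large drop in the size of this substituent, from 10 heavy atoms to 3, with no loss in this read-out, although no information is available here to explain the result.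

As far as these compounds go, whether this tolerance extends to a longer chain such as hexyl, or to a saturated ring such as cyclohexyl, remains open. Also open, from the compounds shown here alone, is how a propyl chain ending in an amine or a carboxylic acid would compare with propyl itself at this place.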